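A few compounds are considered here, and "the series" means these few. Any claim that something is new, unique, unknown or untested is made for them only; others in the source may bear on it.

Three related compounds have been measured in a functional assay on RS4-11 cells (Homo sapiens) for inhibition, read by CCK-8 assay, with a stated time of 72 h; a higher number here means a weaker inhibitor, a lower number a stronger inhibitor. Compound 1 `CC1(C)CCC(CN2CCN(c3ccc(C(=O)NS(=O)(=O)c4ccc(NCC5CCOCC5)c([N+](=O)[O-])c4)c(Oc4cnc5[nH]ccc5c4)c3)CC2)=C(c2ccccc2C(F)(F)F)C1` gives 18 nM, compound 2 `CC(C)C(=O)N1CCC(CNc2ccc(S(=O)(=O)NC(=O)c3ccc(N4CCN(CC5=C(c6ccc(C(F)(F)F)cc6)CC(C)(C)CC5)CC4)cc3Oc3cnc4[nH]ccc4c3)cc2[N+](=O)[O-])CC1` gives 5.3 nM, and compound 3 `CC1(C)CCC(CN2CCN(c3ccc(C(=O)NS(=O)(=O)c4ccc(OCC5CCOCC5)c([N+](=O)[O-])c4)c(Oc4cnc5[nH]ccc5c4)c3)CC2)=C(c2ccc(C(F)(F)F)cc2)C1` gives 5.9 nM. Compound 3 therefore lies within the scatter of compound 2, and its number is clearly lower than that of compound 1, which marks it as the stronger inhibitor of that pair.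

Compound 4 `CCN1CCC(COc2ccc(S(=O)(=O)NC(=O)c3ccc(N4CCN(CC5=C(c6ccc(C(F)(F)F)cc6)CC(C)(C)CC5)CC4)cc3Oc3cnc4[nH]ccc4c3)cc2[N+](=O)[O-])CC1` departs from compound 3 at one place, on a saturated chain carbon bound to an oxygen on an aromatic ring: 1-ethylpiperidin-4-yl in place of oxan-4-yl on a saturated chain carbon bound to an oxygen on an aromatic ring. Within the data shown here, no measured pair isolates this change, so the expectation rests on limited evidence. Compound 2 also differs from compound 3 at this end of the molecule, yet compound 2 gives 5.3 nM, which stays within the scatter of compound 3. No step beyond the scatter is therefore expected in this assay, and the estimated step is a 1.2-fold higher number from compound 3 to compound 4 (0.07 log units; within the scatter). Compound 4 is expected at 7 nM, with an estimated range of 2.5 nM to 20 nM.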

Compound 4, half-maximal inhibitory concentration: 4.9 nM
Beside the measured number, compound 4's estimate is 1.4-fold (0.15 log units) above it; measured number inside the range.
By their numbers in this assay, from the lowest: compounds 4, 2 and 3 (each within the scatter of the next); then compound 1.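

This pair isolates one change at this position, on a saturated chain carbon bound to an oxygen on an aromatic ring. In this assay the exchange of oxan-4-yl for 1-ethylpiperidin-4-yl gives a 1.2-fold lower number from compound 3 to compound 4 (0.08 log units; within the scatter) and so leaves the reading unchanged within the scatter, even though the entering group replaces the ring oxygen with a ring nitrogen and has 8 heavy atoms against 6. No evidence is available to account for this result.

The pair speaks only for these two groups on the shared core, so it cannot show how far this tolerance extends. Going by these compounds, whether a carboxylic acid, a primary amine or a longer chain on the ring nitrogen would be accommodated equally at this position remains open.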